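From 4-nitrobenzyl to 2-chlorobenzyl: working notes

The source may report more compounds than this note shows. Statements on the series, on what has been measured and on what is new or still open speak of the compounds shown alone.

- compound 1 `O=[N+]([O-])c1cccc(CSc2nnc(-c3ccc4c(c3)OCCO4)n2-c2ccccc2)c1` gives 45200 nM in a functional assay on HeLa cells (Homo sapiens) for antiproliferative activity, read by MTT assay, with a stated time of 24 h (on this read-out higher numbers stand for weaker inhibition and lower numbers for stronger inhibition), here
- compound 2 `O=[N+]([O-])c1ccc(CSc2nnc(-c3ccc4c(c3)OCCO4)n2-c2ccccc2)cc1` gives 36200 nM in this assay here

Compound 2 lies within the scatter of compound 1, so neither leads. Compound 3 `Clc1ccccc1CSc1nnc(-c2ccc3c(c2)OCCO3)n1-c1ccccc1` has 2-chlorophenyl in place of 4-nitrophenyl on a saturated chain carbon bound to a sulfur with the core unchanged. Within the data shown here, the one measured step at this place is a 1.2-fold lower number from compound 1 to compound 2 (0.10 log units; within the scatter) and it only exchanges 3-nitrophenyl for 4-nitrophenyl. Among the measured compounds shown here, no measured compound carries chlorine, so guidance is thin, and no shift beyond the scatter is expected in this assay for now. The expected step is a 1.1-fold lower number from compound 2 to compound 3 (0.04 log units; within the scatter) on present data. For compound 3 the estimated value is 33000 nM with an expected range of 12000 nM to 90000 nM overall.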

Compound 3, half-maximal inhibitory concentration: 29000 nM
The estimate for compound 3 lay 1.1-fold (0.06 log units) above the measured number, and the stated range covers the measured number.
By their numbers in this assay, from the lowest: compounds 3, 2 and 1 (each within the scatter of the next).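

At this place, on a saturated chain carbon bound to a sulfur, 2-chlorophenyl joins the two nitrophenyl groups without separating from them in this assay, with a 1.2-fold lower number from compound 2 to compound 3 (0.10 log units; within the scatter) and a 1.6-fold lower number from compound 1 to compound 3 (0.19 log units; within the scatter) as the printed steps. The series thus tolerates the exchange of the nitro group for chlorine, and of the hydrogen-bond acceptors counted on 4-nitrophenyl, with no shift beyond the scatter. No supporting evidence bears on this result.

From the compounds shown here alone, whether an amine, a carboxylic acid or a longer chain at this place would give a shift beyond the scatter remains open. So does the effect of any change to the shared core.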